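Swapping a Propylamide for a Carboxylic Acid

The compounds below may be only part of what the source reports. "The series", "measured", "known", "first", "only" and "open" are said of these compounds alone.

Measured so far:
- compound 1 `C=CC1=C(C(=O)NCCC)C(c2ccc(Cl)c(Cl)c2)OC1` — > 100000 nM
- compound 2 `C=CC1=C(C(=O)O)C(c2ccc(OC)c(OC)c2)OC1` — 18000 nM

Both compounds were tested in a functional assay on HeLa cells (Homo sapiens) for cytotoxicity, read by MTT assay, with a stated time of 24 h; on this read-out higher numbers stand for weaker inhibition and lower numbers for stronger inhibition. For compound 1 the result is not a number but a limit of the assay, > 100000 nM, so compound 1 stands at the edge of what this assay can report, as noted in the limit of > 100000 nM in this assay, at which 1 of the 2 values shown sits. Compound 2, which carries a carboxylic acid and a dimethoxyphenyl group on the shared core, gives a measured value of 18000 nM in this assay.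

Compound 3 `C=CC1=C(C(=O)O)C(c2ccc(Cl)c(Cl)c2)OC1` has not yet been measured. It differs from compound 1 in one place: hydroxy in place of propylamino on a carbonyl carbon. For the measured compounds named here, no directly measured pair shows this exact change, so any expectation rests on compound 2, whose value of 18000 nM shows that an acid on this core can reach a measurable number.

Compound 3 is expected to come in near 30000 nM, in a range from 8000 nM to 150000 nM. This expectation means a step of an at least 3.3-fold lower number from compound 1 to compound 3 (0.52 log units; beyond the scatter) toward stronger inhibition, though its size cannot be fixed while compound 1 shows only a limit.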

Compound 3, half-maximal inhibitory concentration: 10300 nM
Beside the measured number, compound 3's estimate is 2.9-fold (0.46 log units) above it; the measured number falls inside the stated range.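

Compounds 1 and 2 differ in more than one place, so they could not isolate this change, but compounds 1 and 3 differ only on a carbonyl carbon whose other neighbour is a double-bonded ring carbon. In this assay, hydroxy in place of propylamino at this place gives an at least 9.7-fold lower number from compound 1 to compound 3 (0.98 log units; beyond the scatter), so with the rest of the molecule unchanged, this single swap is enough to bring a measurable value within the range of the assay. Compound 1 gives > 100000 nM, which is a limit and not a number, so the step has a known minimum but no known full size: the limit of > 100000 nM in this assay, at which 1 of the 3 values shown sits.

The compounds shown leave open whether the gain depends on the carboxy group itself or simply on the loss of the propylcarbamoyl group. A methyl ester, a primary amide or an amide with a shorter chain, such as ethyl, at the same place would help separate these two readings, and would show how much of the step belongs to the propyl chain.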